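This account rests on a few compounds, and the source may have more. Where it says the series, first, only, none or still open, it means among the compounds named here.

Of the compounds shown here, two have been measured in a functional assay on A549 cells (Homo sapiens) for antiproliferative activity, read by MTT assay, with a stated time of 48 h; on this read-out higher numbers stand for weaker inhibition and lower numbers for stronger inhibition. Compound 2 `Cc1ccccc1-n1nncc1CN1C(=O)C2(C(C#N)=C(N)Oc3c(N)cc4nc5ccccc5nc4c32)c2ccccc21` gives 31700 nM; compound 1 `CCOc1ccc(-n2nncc2CN2C(=O)C3(C(C#N)=C(N)Oc4c3c3nc5ccccc5nc3c3ccccc43)c3ccccc32)cc1` gives 25200 nM, and the two values lie within the scatter of each other, so neither stands apart. Compound 3 `N#CC1=C(N)Oc2c(N)cc3nc4ccccc4nc3c2C12C(=O)N(Cc1cnnn1-c1ccc(Cl)cc1)c1ccccc12` is not yet measured. It differs from compound 2 in one place: 4-chlorophenyl in place of 2-methylphenyl on an aromatic nitrogen. Among the compounds with values here, no measured pair shows this exchange, so nothing fixes its effect. In this assay the step of a 1.1-fold lower number from compound 2 to compound 3 (0.02 log units; within the scatter) is expected to stay within the scatter, in no set direction. Compound 3 is therefore estimated at 30000 nM, with a range from 12000 nM to 75000 nM.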

Compound 3, half-maximal inhibitory concentration: > 50000 nM
Compound 3 ended at the assay's limit; the forecaster's own chance of this, stated with the estimate: 10%; middle value at least 1.6-fold (0.22 log units) away from the limit.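

In this assay, compound 3 gives > 50000 nM, which is a limit of the assay and not a number. The first step read at this position is an at least 1.5-fold higher number from compound 2 to compound 3 (0.19 log units; that floor lies within the scatter), so 4-chlorophenyl in place of 2-methylphenyl on the aromatic nitrogen brings no gain in inhibition, while the size of any loss stays unfixed. The reading of compound 3 stops at the assay's ceiling: the limit of > 50000 nM in this assay, at which 1 of the 3 values shown sits.

Open, going by these compounds, is whether the change of substituent or its place on the phenyl ring matters here. Also open, on these data alone, is how 2-chlorophenyl, 4-methylphenyl or an unsubstituted phenyl would read on this nitrogen.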